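Indolyl to Fluorophenyl on the Shared Core

The source may hold more compounds than are shown below. What is called first, only, known or untested is meant among the compounds shown, and "the series" means these compounds.

Of the compounds shown here, three have so far been tested in a functional assay on B16-F0 cells (Mus musculus) for inhibition, read by CCK-8 assay, with a stated time of 48 h; a higher number here means a weaker inhibitor, a lower number a stronger inhibitor. Among the measured compounds shown here, compound 2 `COc1cc(-c2ccnc3cc(-c4c[nH]c5ccccc45)nn23)cc(OC)c1OC` is the only one that returns a number, giving 40 nM. Compound 1 `COc1cc(-c2ccnc3c(-c4ccc(C)cc4)cnn23)cc(OC)c1OC` reaches only the limit of the assay, reported as > 10000 nM. Compound 3 `Cc1ccc(-c2cc3nccc(-c4ccc(F)cc4)n3n2)cc1` likewise stops at the limit, reported as > 10000 nM. Compound 2 therefore stands alone with a measured value, while the other two rest at the limit of > 10000 nM in this assay, at which 2 of the 3 values shown sit. For the measured compounds named here, no pair among the three differs in a single place, so no measured step is available to follow.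

Compound 4 `COc1cc(-c2ccnc3cc(-c4ccc(F)cc4)nn23)cc(OC)c1OC` has not yet been measured. It differs from compound 2 by a single change: 4-fluorophenyl in place of 1H-indol-3-yl on an aromatic carbon. Compound 3 also carries a 4-fluorophenyl group, on a different carbon of its core, and in this assay compound 3 gives only the limit > 10000 nM. Against that background, the indol-3-yl of compound 2 is the one feature that goes with a measured number.

Compound 4 is expected to lose potency in this assay, with a step of a 38-fold higher number from compound 2 to compound 4 (1.57 log units; beyond the scatter) beyond the usual scatter. Compound 4 is estimated at 1500 nM, within a range from 200 nM to 10000 nM.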

Compound 4, half-maximal inhibitory concentration: 4540 nM
Compound 4: the middle estimate sits 3.0-fold (0.48 log units) below what was measured, within the range that was stated.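

Among the compounds shown here, the replacement of 1H-indol-3-yl by 4-fluorophenyl gives the first single change that can be read in this assay, a 110-fold higher number from compound 2 to compound 4 (2.05 log units; beyond the scatter), and it shows that the group on this aromatic carbon of the five-membered aromatic ring with 2 nitrogen strongly affects the number on the shared core. The change replaces two aromatic rings with one and also removes the one hydrogen-bond donor counted in the leaving group, and this single step cannot separate those differences. Compound 4 still returns a measured number, so this change does not take the shared core to the limit, which is a limit of the assay and not a number: the limit of > 10000 nM in this assay, at which 2 of the 4 values shown sit.

From the compounds shown here alone, it remains open how a 1-methyl-1H-indol-3-yl group, which keeps both rings but has a methyl on the indole nitrogen, or a 4-aminophenyl group would read at this carbon in this assay. Also open is whether the same exchange would give a step of similar size on another core, as this is the only pair shown that differs at this place.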